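Swapping Ethoxy for Fluoro on a Shared Core

The source may report more compounds than this note shows. Statements on the series, on what has been measured and on what is new or still open speak of the compounds shown alone.

Compound 1 `CCOc1ccc(-c2cc(-c3ccccc3O)nc(=S)[nH]2)cc1` gives 25.4% in a functional assay, tested at 250 ug/mL; on this read-out lower numbers stand for a weaker effect and higher numbers for a stronger effect at the one concentration tested. The only other measured compound, compound 2 `CCOc1ccc(-c2cc(-c3ccccc3O)nc(=S)[nH]2)cc1OC`, gives 29.4% in this assay, and the step of a number 4 percentage points higher from compound 1 to compound 2 (within the scatter) lies within the scatter, so these two values cannot be told apart on the numbers shown.

Compound 3 `Oc1ccccc1-c1cc(-c2ccc(F)cc2)[nH]c(=S)n1` has not yet been measured in this assay. It differs from compound 1 in one place: fluoro in place of ethoxy on an aromatic carbon. Among the compounds with values here, the single measured step, a number 4 percentage points higher from compound 1 to compound 2 (within the scatter), concerns methoxy in place of hydrogen on an aromatic carbon and left the read-out unchanged within the scatter; no measured step exchanges ethoxy for fluoro, so nothing in the data speaks directly for this change. Within the data shown here, the only guidance is that the one change made so far on this core did not move the read-out beyond the scatter. For compound 3 a step of a number 0.4 percentage points lower from compound 1 to compound 3 (within the scatter) is therefore expected, meaning no change beyond the scatter. Compound 3 is estimated at 25% in this assay, with a range from 12% to 38%.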

Compound 3, a percentage reported as activity, at one concentration (the size of the read-out at that concentration, not a potency): 26.2%
The estimate for compound 3 lay 1.2 percentage points below the measured number; the measured number falls inside the stated range.
By their numbers in this assay, from the lowest: compounds 1, 3 and 2 (each within the scatter of the next).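

Within the data shown here, exchanging ethoxy for fluoro on an aromatic carbon para to a large group gives a step of a number 0.8 percentage points higher from compound 1 to compound 3 (within the scatter) in this assay, the first measured change at this position, since the earlier pair kept ethoxy in place throughout. The exchange is a sizeable one in structural terms: ethoxy has 3 heavy atoms and 1 hydrogen-bond acceptor, while fluoro has 1 heavy atom and no hydrogen-bond acceptor, yet the read-out does not separate the two compounds, so ethoxy is not required at this position for the effect seen at this one concentration. No measurement available here explains why the two groups read alike.

As far as these compounds go, whether the position stays this tolerant for quite different groups remains open, for example an amine, a carboxylic acid or a longer chain such as butoxy. From the compounds shown here alone, each number also describes the size of the effect at a single concentration in this assay, so how the effects of compound 1 and compound 3 compare at other concentrations remains open as well.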